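Naphthalene for bromophenyl on a fused thiazole core

A few compounds are considered here, and "the series" means these few. Any claim that something is new, unique, unknown or untested is made for them only; others in the source may bear on it.

Measured so far:
compound 1, `Clc1ccc(CO/N=C/c2c(-c3ccc4ccccc4c3)nc3occn23)cc1Cl`: 370 nM
compound 2, `Clc1ccc(CO/N=C/c2c(-c3ccc(Br)cc3)nc3sccn23)cc1Cl`: 480 nM

In an assay on HepG2 cells for agonist activity at nuclear receptor subfamily 1 group I member 3 (Homo sapiens), read by a luciferase reporter, with a stated time of 23 h (a higher number here means that more compound is needed for the effect, a lower number that less compound is needed), compound 2 gives 480 nM and compound 1 gives 370 nM; the two numbers lie within the usual scatter of each other, so neither stands apart. Compound 3, `Clc1ccc(CO/N=C/c2c(-c3ccc4ccccc4c3)nc3sccn23)cc1Cl`, has not been measured in this assay. It differs from compound 2 in one place: naphthalen-2-yl in place of 4-bromophenyl on an aromatic carbon. For the measured compounds named here, no measured pair shows this change alone, so its size is unknown. The step of a 1.2-fold lower number from compound 2 to compound 3 (0.08 log units; within the scatter) is expected to stay within the scatter, with no clear direction. Compound 3 is therefore estimated at 400 nM, between 180 nM and 900 nM.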

Compound 3, half-maximal effective concentration: 380 nM
Compound 3: the middle estimate sits 1.1-fold (0.02 log units) above what was measured, and the stated range covers the measured number.
By their numbers in this assay, from the lowest: compounds 1, 3 and 2 (each within the scatter of the next).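

In this assay, putting naphthalen-2-yl in place of 4-bromophenyl on this aromatic carbon gives a 1.3-fold lower number from compound 2 to compound 3 (0.10 log units; within the scatter). The two numbers cannot be told apart, so at this position, on this core, a group with two six-membered aromatic rings of carbon serves as well as one with a single bromine-bearing ring. No separate measurement explains this result.

Still open, as far as these compounds go, is whether this tolerance extends to groups of a different kind. An amine or a carboxylic acid on the ring at this position could give a very different number.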